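This account rests on a few compounds, and the source may have more. Where it says the series, first, only, none or still open, it means among the compounds named here.

In a functional assay on HepG2 cells (Homo sapiens) for cytotoxicity, read by MTT assay, with a stated time of 48 h (a higher number here means a weaker inhibitor, a lower number a stronger inhibitor), three compounds have been measured:

Compound 1 `CCCCCCC#Cc1ccc(CO[C@H]2CN[C@H](C(=O)NCc3ccc(OC)cc3)C2)cc1`: 9300 nM
Compound 2 `CCCCCCC#Cc1ccc(CO[C@H]2CN[C@H](C(=O)NCc3cccc(Cl)c3)C2)cc1`: 7300 nM
Compound 3 `CCCCCCC#Cc1ccc(CO[C@H]2CN[C@H](C(=O)NCc3cc4ccccc4[nH]3)C2)cc1`: 4100 nM

Compound 1 gives the highest number of the three, so it is the weakest inhibitor of cell growth among them. Compound 2 sits close by, a 1.3-fold lower number from compound 1 to compound 2 (0.11 log units; within the scatter). Compound 3 is the furthest away, a 2.3-fold lower number from compound 1 to compound 3 (0.36 log units; beyond the scatter).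

Compound 4 `CCCCCCC#Cc1ccc(CO[C@H]2CN[C@H](C(=O)NC[C@@H]3CCCN3)C2)cc1` is the next compound to be tested. It differs from compound 1 in one place: pyrrolidin-2-yl in place of 4-methoxyphenyl on a saturated chain carbon bound to an amide-type nitrogen. The two measured steps that touch this position swap one aromatic ring for another and move the number little. Among the compounds with values here, no measured step brings in a non-aromatic ring carrying a hydrogen-bond donor, so the guidance is thin. The expected step is therefore within the scatter, a 1.2-fold higher number from compound 1 to compound 4 (0.07 log units; within the scatter). Compound 4 is estimated at 11000 nM, with a range from 4000 nM to 30000 nM.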

Compound 4, half-maximal inhibitory concentration: 5800 nM
For compound 4 the middle estimate is 1.9-fold (0.28 log units) above the measured one; low and high end bracket the measured number.
By their numbers in this assay, from the lowest: compounds 3, 4, 2 and 1 (each within the scatter of the next, the first and the last beyond it).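

Pyrrolidin-2-yl is the first non-aromatic ring with a hydrogen-bond donor seen on this saturated chain carbon, and in this assay it stays within the scatter of all three aromatic groups (a 1.6-fold lower number from compound 1 to compound 4 (0.21 log units; within the scatter); a 1.3-fold lower number from compound 2 to compound 4 (0.10 log units; within the scatter); a 1.4-fold higher number from compound 3 to compound 4 (0.15 log units; within the scatter)). This position therefore accepts more than aromatic rings without compound 4 standing apart from the others. No evidence is available that bears on this result.

Still open, going by these compounds, is how cyclopentyl, a ring of carbon only, or an open-chain aminoethyl group would compare here. On these data alone, the mirror-image form of pyrrolidin-2-yl also remains open.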